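Chloro in place of phenyl: compound 2 to compound 3

This account rests on a few compounds, and the source may have more. Where it says the series, first, only, none or still open, it means among the compounds named here.

Of the compounds shown here, two have been measured so far in an assay on CHO cells for displacement of a labelled ligand from prostaglandin E2 receptor EP1 subtype (Mus musculus), read by scintillation counting, with a stated time of 20 min; a higher number here means a weaker inhibitor, a lower number a stronger inhibitor. Compound 1 `CCCc1cccc(C[C@H](O)/C=C/[C@H]2CCC(=S)N2CCCCCCC(=O)O)c1` gives > 10000 nM, which is a limit of the assay and not a number. Compound 2 `O=C(O)CCCSCCN1C(=O)OC[C@@H]1/C=C/[C@@H](O)Cc1cccc(-c2ccccc2)c1` gives in this assay > 10000 nM, again only a limit. Both values thus sit at the limit of > 10000 nM in this assay, at which 2 of the 2 values shown sit; on the numbers shown, compound 2 stands at the limit, with no measured step to place it against, since the two measured structures differ in more than one place.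

Compound 3 `O=C(O)CCCSCCN1C(=O)OC[C@@H]1/C=C/[C@@H](O)Cc1cccc(Cl)c1` is the next to be measured in this assay. It differs from compound 2 by chloro in place of phenyl on an aromatic carbon. Within the data shown here, no step between measured compounds is available against which to judge this change, and with both measured values at the limit no direction can be read from the data. The expectation is that the change does not move the value beyond the scatter and that compound 3 stays at the limit. The expected step is a step that the limit leaves unreadable from compound 2 to compound 3. Compound 3 is estimated at 15000 nM, within 5000 nM to 50000 nM.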

Compound 3, inhibition constant: > 10000 nM
Compound 3: no number, only a limit (the forecaster's own chance of this, stated with the estimate: 80%); the middle value is on the limit's open side.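

In this assay compound 3 gives > 10000 nM, a limit of the assay and not a number. No step can be read between compound 2 and compound 3, because both stand at a limit: the limit of > 10000 nM in this assay, at which 3 of the 3 values shown sit.

The compounds shown leave open how chloro and phenyl compare on this aromatic carbon, as none has a measured inhibition constant.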